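A few compounds are considered here, and "the series" means these few. Any claim that something is new, unique, unknown or untested is made for them only; others in the source may bear on it.

Compound 1 `COC(=O)C1=C(C)N=C(C)/C(=C(/O)OC)C1c1ccccc1OCCO[N+](=O)[O-]`: 56 nM
Compound 2 `COC(=O)C1=C(C)N=C(C)/C(=C(/O)OC)C1c1cccc(OCc2nonc2C)c1`: 640 nM

In a functional assay (aorta) with Rattus norvegicus as the target, in the presence of a further agent that is not named here (on this read-out higher numbers stand for an effect only at larger amounts of compound and lower numbers for an effect already at smaller amounts), compound 1 gives 56 nM. Compound 2 stands highest at 640 nM. The gap between these two compounds lies beyond the scatter. Compound 3 `COC(=O)C1=C(C)N=C(C)/C(=C(/O)OC)C1c1cccc(OCc2no[n+]([O-])c2C#N)c1` keeps the core of compound 2 and exchanges the ring group on a saturated chain carbon bound to an oxygen on an aromatic ring: a group of 8 heavy atoms (3 carbon, 3 nitrogen, 2 oxygen; one five-membered aromatic ring with 3 hetero atoms) in place of a group of 6 heavy atoms (3 carbon, 2 nitrogen, 1 oxygen; one five-membered aromatic ring with 3 hetero atoms), on a saturated chain carbon bound to an oxygen on an aromatic ring. Within the data shown here, no measured pair shows what such an exchange does. Among the measured compounds shown here, compound 1, at 56 nM, shows only that this core can reach a much lower number with another side group, so a clear fall is expected. The expected change is a 6.4-fold lower number from compound 2 to compound 3 (0.81 log units; beyond the scatter), beyond the scatter. For compound 3 the estimated value is 100 nM, with an expected range of 15 nM to 600 nM.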

Compound 3, half-maximal effective concentration: 3.3 nM
Compound 3: the middle estimate sits 30-fold (1.48 log units) above what was measured; measured number below the stated range.
By their numbers in this assay, from the lowest: compound 3; then compound 1; then compound 2.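

In this assay the exchange of the 4-methyl-1,2,5-oxadiazol-3-yl group for the larger group with a triple bond brings a 190-fold lower number from compound 2 to compound 3 (2.29 log units; beyond the scatter) and so shows how strongly the number depends on the group at this place. Both groups hold one five-membered aromatic ring with 3 hetero atoms, so a change within a ring of this kind can be enough. Nothing here explains the size of this step. From the compounds shown here alone, whether the nitrile or the added oxygen carries the step stays open. A carboxamide in place of the nitrile, or a longer chain to the ring, remains untested in the compounds shown.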